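Branched alkyl ether in place of a trifluoroethyl chain

The compounds below may be only part of what the source reports. "The series", "measured", "known", "first", "only" and "open" are said of these compounds alone.

Compound 2 `Nc1ccc2cccc(OCCC(F)(F)F)c2n1` stands second highest of the three numbers in an assay on cells with melanin-concentrating hormone receptor 1 (Homo sapiens) as the target, read by radioligand binding; on this read-out lower numbers stand for stronger inhibition and higher numbers for weaker inhibition: compound 2 gives 722 nM, compound 3 `Nc1ccc2cccc(OCCC3CCCCC3)c2n1` gives 808 nM, and compound 1 `CC1CCCCC1Oc1cccc2ccc(N)nc12` gives 32 nM. Compound 4 `CCC(C)COc1cccc2ccc(N)nc12` differs from compound 2 by sec-butyl in place of 2,2,2-trifluoroethyl on a saturated chain carbon bound to an oxygen on an aromatic ring. Within the data shown here, only one measured step touches this region of the shared core: a 1.1-fold higher number from compound 2 to compound 3 (0.05 log units; within the scatter), a change two bonds along the chain, so it says little about a change on the carbon bound to the oxygen itself. Among the measured compounds shown here, compound 1 and compound 2 show that a branched saturated group placed directly on the oxygen goes with a markedly lower number than a chain, though no single-place step connects them. On that basis compound 4, with its sec-butyl group sitting directly on the oxygen, is expected to fall between compound 2 and compound 1, as a 4.8-fold lower number from compound 2 to compound 4 (0.68 log units; beyond the scatter). The estimate for compound 4 in this assay is 150 nM, within a range of 40 nM to 500 nM.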

Compound 4, half-maximal inhibitory concentration: 36 nM
Compound 4: middle estimate off by 4.2-fold (0.62 log units), on the high side; measured number below the stated range.
By their numbers in this assay, from the lowest: compounds 1 and 4 (each within the scatter of the next); then compounds 2 and 3 (each within the scatter of the next).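

In this assay, among these compounds, sec-butyl in place of 2,2,2-trifluoroethyl on a saturated chain carbon bound to an oxygen on an aromatic ring gives a 20-fold lower number from compound 2 to compound 4 (1.30 log units; beyond the scatter), so the number responds strongly to a change here, which the one earlier step did not show. That earlier step also removes the fluorine atoms, yet it reads a 1.1-fold higher number from compound 2 to compound 3 (0.05 log units; within the scatter), so among these compounds their loss alone does not go with a lower number. Nothing available here explains the size of this change. From the compounds shown here alone, whether the branch matters remains open, since no unbranched pentyl chain stands beside the 2-methylbutyl group of compound 4. Going by these compounds, how an amine or a carboxylic acid on that chain would read also remains open.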